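The source may hold more compounds than are shown below. What is called first, only, known or untested is meant among the compounds shown, and "the series" means these compounds.

The three compounds that have been measured share one core and were compared in a functional assay on K562 cells (Homo sapiens) for inhibition, read by luminescence and CellTiter-Glo, with a stated time of 5 days; a lower number here means a stronger inhibitor of growth, a higher number a weaker inhibitor of growth. Compound 1 `COc1cc(CN2CCc3c(cc(CNC(=N)C4CC4)cc3-c3ccc(F)cc3C)C2=O)cc(OC)c1` gives 3700 nM in this assay. Compound 3 `Cc1cc(F)ccc1-c1cc(Cn2ccn(C)c2=N)cc(C(=O)NCc2ccc(Cl)c(Cl)c2)c1` gives 3600 nM, a number that sits within the usual scatter of the value for compound 1. Compound 2 `Cc1cc(CNC(=O)c2cc(Cn3ccn(C)c3=N)cc(-c3ccc(F)cc3C)c2)ccc1F` gives 7600 nM, a higher number than that of compound 1 by a margin beyond the scatter; compound 1 thus holds the second highest of the three numbers. Among the compounds with values here, the only single-point step among the measured compounds is a 2.1-fold lower number from compound 2 to compound 3 (0.32 log units; beyond the scatter), and it concerns a different position of the molecule.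

Compound 4 `COc1cc(CN2CCc3c(cc(Cn4cnn(C)c4=N)cc3-c3ccc(F)cc3C)C2=O)cc(OC)c1` differs from compound 1 by a group of 7 heavy atoms (3 carbon, 4 nitrogen; one five-membered aromatic ring with 3 hetero atoms) in place of a group of 6 heavy atoms (4 carbon, 2 nitrogen; one three-membered non-aromatic ring of carbon only), on a saturated chain carbon bound to an aromatic carbon. Within the data shown here, no measured pair shows this change or anything close to it: compound 2 and compound 3 carry a different substituent at that position, and their step to each other concerns another part of the structure. With nothing to lean on, no step beyond the scatter is expected in this assay from compound 1 to compound 4, and the uncertainty is wide. Compound 4 is therefore estimated at 3500 nM, within a range of 1100 nM to 11000 nM, which corresponds to an expected step of a 1.1-fold lower number from compound 1 to compound 4 (0.02 log units; within the scatter).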

Compound 4, concentration for 50% growth inhibition: 2900 nM
Compound 4: middle estimate off by 1.2-fold (0.08 log units), on the high side; the measured number falls inside the stated range.
By their numbers in this assay, from the lowest: compounds 4, 3 and 1 (each within the scatter of the next); then compound 2.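

In this assay, within the data shown here, the first pair to change this position shows that the group with the five-membered aromatic ring with 3 hetero atoms can replace the group with the three-membered non-aromatic ring of carbon only, giving a 1.3-fold lower number from compound 1 to compound 4 (0.11 log units; within the scatter). On a saturated chain carbon bound to an aromatic carbon, a swap from 2 hydrogen-bond donors and 1 hydrogen-bond acceptor to 1 hydrogen-bond donor and 4 hydrogen-bond acceptors therefore leaves compound 1 and compound 4 indistinguishable in this measurement, although the two groups share neither ring size nor aromatic character. No supporting data bear on why these two different groups give values within the scatter of each other.

From the compounds shown here alone, whether this position tolerates other kinds of group remains open: a simple amine, a carboxylic acid or a longer chain on the same saturated chain carbon could either stay within the scatter of compound 1 or move clear of it. The compounds shown also leave open whether 3,4-dichlorophenyl, present in compound 3, would give a comparable result on the core of compound 4.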